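Aryl swap on the free-amine dithiocarbamate triazole

The source may report more compounds than this note shows. Statements on the series, on what has been measured and on what is new or still open speak of the compounds shown alone.

The series is followed in a functional assay on ECa-109 cells (Homo sapiens) for inhibition, read by MTT assay, with a stated time of 72 h; a higher number here means a weaker inhibitor, a lower number a stronger inhibitor. Compound 1 `CC(C)(C)OC(=O)N1CCN(C(=S)SCc2cn(Cc3ccc(Cl)cc3)nn2)CC1` carries a tert-butoxycarbonyl group on the ring amine nitrogen and a 4-chlorophenyl group. In this assay compound 1 reaches only the limit > 128000 nM, which is not a number. Compound 2 `S=C(SCc1cn(Cc2ccc(Cl)c(Cl)c2)nn1)N1CCNCC1` has a free amine nitrogen in its ring and a 3,4-dichlorophenyl group. In this assay compound 2 also sits at the limit > 128000 nM. Compound 3 `O=C(OCc1ccccc1)N1CCN(C(=S)SCc2cn(Cc3ccc(Cl)c(Cl)c3)nn2)CC1` is the benzyloxycarbonyl derivative of compound 2, and in this assay compound 3 gives 29400 nM. Among the measured compounds shown here, the only resolved step is an at least 4.3-fold lower number from compound 2 to compound 3 (0.63 log units; beyond the scatter), benzyloxycarbonyl in place of hydrogen on an amine nitrogen in a ring. Compound 2 therefore stands at the weak end of what is shown, resting on the limit described by the limit of > 128000 nM in this assay, at which 2 of the 3 values shown sit.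

Compound 4 `Cc1ccc(Cn2cc(CSC(=S)N3CCNCC3)nn2)cc1` keeps the free amine nitrogen of compound 2 and changes the aryl group: 4-methylphenyl in place of 3,4-dichlorophenyl on a saturated chain carbon bound to an aromatic nitrogen. No measured step touches this position; compounds 1 and 2 differ both in the aryl group and at the ring amine nitrogen, so the aryl change cannot be isolated from the numbers shown. Compound 4 is therefore expected to give about 150000 nM, with a range from 50000 nM to 450000 nM, and most likely again a limit. The expected step is a step that the limit leaves unreadable from compound 2 to compound 4, that is, nothing beyond the scatter.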

Compound 4, half-maximal inhibitory concentration: > 128000 nM
Compound 4 ended at the assay's limit; the forecaster's own chance of this, stated with the estimate: 70%; the middle value is on the limit's open side.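

In this assay compound 4 gives > 128000 nM, which is a limit and not a number. Compound 2 rests on the same limit, so no step can be read between compound 2 and compound 4: the limit of > 128000 nM in this assay, at which 3 of the 4 values shown sit.

Open, on these data alone, is whether the aryl group affects the value when the ring amine nitrogen carries benzyloxycarbonyl, as in compound 3.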